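The compounds below may be only part of what the source reports. "The series", "measured", "known", "first", "only" and "open" are said of these compounds alone.

Measured so far:
- compound 1 `CCC(=O)N1C=Cc2nc(N3CCN(Cc4ccc(F)cc4F)CC3)c(NC(C)C)nc2C1`: 30000 nM
- compound 2 `CC(=O)N1C=Cc2nc(NC3CC3)c(N3CCC(Oc4ccc(F)cc4F)CC3)nc2C1`: 34000 nM
- compound 3 `CC(C)Nc1nc2c(nc1N1CCC(Oc3ccc(F)cc3F)CC1)C=CNC2`: 100000 nM

In a functional assay on CHO-K1 cells for agonist activity at G-protein coupled receptor 6 (Homo sapiens), read by TR-FRET and cAMP accumulation, with a stated time of 20 h (on this read-out higher numbers stand for an effect only at larger amounts of compound and lower numbers for an effect already at smaller amounts), compound 3 gives the highest number of the three, and its gaps to compound 2 and to compound 1 both lie beyond the usual scatter. Compound 4 `CC(C)Nc1nc2c(nc1N1CCC(Oc3ccc(F)cc3F)CC1)C=CN(C)C2` differs from compound 3 by one change: methyl in place of hydrogen on an amine nitrogen in a ring. For the measured compounds named here, no direct step between measured compounds covers this change. Compound 1 and compound 2 each carry a larger group on that ring nitrogen and show lower numbers than compound 3, but they also differ elsewhere, so the effect of the methyl alone cannot be read off. A small step toward a lower number is expected. Compound 4 is estimated at 70000 nM (range 25000 nM to 200000 nM), which as an expected step means a 1.4-fold lower number from compound 3 to compound 4 (0.15 log units; within the scatter).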

Compound 4, half-maximal effective concentration: 89000 nM
For compound 4 the middle estimate is 1.3-fold (0.10 log units) below the measured one; measured number inside the range.
By their numbers in this assay, from the lowest: compounds 1 and 2 (each within the scatter of the next); then compounds 4 and 3 (each within the scatter of the next).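

In this assay, methyl in place of hydrogen on this amine nitrogen in a ring gives a 1.1-fold lower number from compound 3 to compound 4 (0.05 log units; within the scatter). For the compounds shown here, this is the first comparison at this position in which nothing else differs, and it shows that adding one carbon here leaves the two values within the usual scatter of each other. No measurement at hand offers a reason for this result. As far as these compounds go, whether a longer chain such as butyl, or a benzyl group, on the same nitrogen would give a step beyond the scatter remains open.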